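Methoxy for fluoro on a nitroisoxazole amide: expected tolerance

The compounds below may be only part of what the source reports. "The series", "measured", "known", "first", "only" and "open" are said of these compounds alone.

Measured compounds:
Compound 1, `O=C(NCc1ccc(F)cc1)c1c([N+](=O)[O-])noc1-c1ccc(Cl)cc1`, gives 91900 nM in an ADME assay on J774.A1 cells (Mus musculus) for cytotoxicity, read by MTT assay, with a stated time of 48 h; a higher number here means that more compound is tolerated, a lower number that less compound is tolerated.
Compound 2, `COc1ccc(CNC(=O)c2c([N+](=O)[O-])noc2-c2ccc(Cl)cc2)cc1`, gives 89500 nM in this assay.
Compound 3, `O=C(NCc1ccc(F)cc1)c1c([N+](=O)[O-])noc1-c1ccc(Cl)cc1Cl`, gives 86400 nM in this assay.

All three compounds share one core, an amide that carries a benzyl group on its nitrogen. Compound 1 and compound 2 differ only on that benzyl group: methoxy in place of fluoro on an aromatic carbon. The measured effect of this change was a 1.0-fold lower number from compound 1 to compound 2 (0.01 log units; within the scatter). Compound 3 differs from compound 1 on the other aryl ring, the one attached directly to the core: chloro in place of hydrogen on an aromatic carbon. That change gave a 1.1-fold lower number from compound 1 to compound 3 (0.03 log units; within the scatter).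

Compound 4, `COc1ccc(CNC(=O)c2c([N+](=O)[O-])noc2-c2ccc(Cl)cc2Cl)cc1`, has not yet been measured in this assay. It relates to compound 3 as compound 2 relates to compound 1: methoxy in place of fluoro on an aromatic carbon. The surroundings of the change are described in the same words in both cases, so this is the same change, made a second time on a core that carries a further chloro group. Because the earlier instance read a 1.0-fold lower number from compound 1 to compound 2 (0.01 log units; within the scatter), the expectation is that the step from compound 3 to compound 4 is also small, estimated as a 1.0-fold lower number from compound 3 to compound 4 (0.01 log units; within the scatter). On that basis compound 4 is expected to give about 85000 nM in this assay, with a plausible range from 45000 nM to 160000 nM. Within the data shown here, only two measured steps support this; nothing beyond these compounds is claimed.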

Compound 4, half-maximal cytotoxic concentration: 80500 nM
The estimate for compound 4 lay 1.1-fold (0.02 log units) above the measured number, and the stated range covers the measured number.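

In this assay, methoxy in place of fluoro on the core with the further chloro group gave a 1.1-fold lower number from compound 3 to compound 4 (0.03 log units; within the scatter), and this second instance agrees with the first: the same change on two cores in this assay, a 1.0-fold lower number (0.01 log units; within the scatter) from compound 1 to compound 2 and a 1.1-fold lower number (0.03 log units; within the scatter) from compound 3 to compound 4, 1.0-fold (0.02 log units) apart, within the scatter of two such steps. Chloro in place of hydrogen, now made on the compounds that carry methoxy, gave a 1.1-fold lower number from compound 2 to compound 4 (0.05 log units; within the scatter), and the two instances of this change also agree: the same change on two cores in this assay, a 1.1-fold lower number (0.03 log units; within the scatter) from compound 1 to compound 3 and a 1.1-fold lower number (0.05 log units; within the scatter) from compound 2 to compound 4, 1.0-fold (0.02 log units) apart, within the scatter of two such steps. Among these compounds, this shows that across these four compounds each change stays within the scatter on both cores, so a small step carried over from one core to the other, but it rests on only two instances of each change and does not show that either change would stay this small on any other core.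

It also cannot show how a change with a larger effect would carry over, since none of the steps here rises above the scatter. What the compounds shown leave open is whether the same flat picture would hold with an amine or a carboxylic acid on the benzyl ring, with a longer chain in place of the benzyl group, or with a group other than nitro on the shared core.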